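The compounds below may be only part of what the source reports. "The series", "measured", "known", "first", "only" and "open" are said of these compounds alone.

Measured compounds:
compound 1, `CCCCC[C@H](CCC[C@@H]1CC=CC(=O)O1)OC`, 14400 nM
compound 2, `CCCCC[C@@H](C[C@@H](O)C[C@H]1CC=CC(=O)O1)OC`, 33700 nM

The account follows a single stereochemical step away from compound 1. In a functional assay on A2780 cells (Homo sapiens) for cytotoxicity, read by MTT assay, with a stated time of 24 h (on this read-out lower numbers stand for stronger inhibition and higher numbers for weaker inhibition), compound 1 gives 14400 nM, the lowest of the two numbers shown. Among the measured compounds shown here, its nearest neighbour is compound 2, which in this assay gives 33700 nM, a number that sits beyond the scatter above compound 1; no structural step between these two is set out, so only their two values speak.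

The unmeasured compound 3, `CCCCC[C@@H](CCC[C@@H]1CC=CC(=O)O1)OC`, differs from compound 1 as follows: the two compounds have the same atoms and bonds and differ only in configuration as drawn: 1 of 2 stereo elements differ; a stereocentre at a saturated chain carbon is drawn R in compound 1 and S in compound 3. For the measured compounds named here, no step between measured compounds is set out for such a change, so nothing in the data fixes its size. The reasonable expectation is a step no larger than the scatter, with no preferred direction, since the pair shares every atom and bond and compound 1 itself is already a weak inhibitor in this assay.

Compound 3 is therefore expected to give about 18000 nM, within a range from 6000 nM to 50000 nM, and the step from compound 1 to compound 3 is estimated at a 1.3-fold higher number from compound 1 to compound 3 (0.10 log units; within the scatter).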

Compound 3, half-maximal inhibitory concentration: 14900 nM
For compound 3 the middle estimate is 1.2-fold (0.08 log units) above the measured one; the measured number falls inside the stated range.
By their numbers in this assay, from the lowest: compounds 1 and 3 (each within the scatter of the next); then compound 2.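

In this assay, turning the stereocentre at the saturated chain carbon from R to S gives a 1.0-fold higher number from compound 1 to compound 3 (0.01 log units; within the scatter). Among the compounds shown here, until this pair, no step of any kind could be read, so this is the first size that can be put on a change at this position, and it shows that this assay does not separate the two configurations drawn at this stereocentre. The comparison concerns configuration alone, with no other part of the structure altered: the fact that compounds 1 and 3 differ only in the configuration as drawn

What the compounds shown leave open is whether the same holds for the other stereo element, since no pair here differs at that centre alone, and compound 2 differs from compound 1 and compound 3 in more than one place, so it cannot show what any single change does. As far as these compounds go, it also remains open whether the indifference to configuration would survive a change of the group itself, for instance an amine or a hydroxyl in place of the methoxy group at this carbon, or a longer chain on it, where the two configurations might no longer give matching numbers.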